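From trifluoromethyl to fluoro on the shared core

The source may hold more compounds than are shown below. What is called first, only, known or untested is meant among the compounds shown, and "the series" means these compounds.

In an ADME assay on microsomes from liver (Homo sapiens) for metabolic stability, with a stated time of 30 min (on this read-out lower numbers stand for a less stable compound and higher numbers for a more stable compound), two compounds sharing one core have been measured so far. Compound 1 `CC(=O)N[C@@H](C)/C=C/c1ccc(Oc2ccc3nc(C(C)C)sc3c2Cl)nc1`, which carries chloro, gives 83%. Compound 2 `CC(=O)N[C@@H](C)/C=C/c1ccc(Oc2ccc3nc(C(C)C)sc3c2C(F)(F)F)nc1`, which carries trifluoromethyl on the same aromatic carbon, gives 87%. These two values lie within the scatter of each other, so compound 2 cannot be ranked ahead of compound 1.

Compound 3 `CC(=O)N[C@@H](C)/C=C/c1ccc(Oc2ccc3nc(C(C)C)sc3c2F)nc1` has not yet been measured. It differs from compound 2 by fluoro in place of trifluoromethyl on an aromatic carbon, with fluoro in place of trifluoromethyl on an aromatic carbon. Among the compounds with values here, only one measured step bears on this change. Within the data shown here, it is the one exchange made at this carbon so far. That step is a number 4 percentage points higher from compound 1 to compound 2 (within the scatter), and it is small. No measurement with fluoro exists yet, so this single step is thin support. Even so, no change beyond the scatter is expected, and the estimated step is a number 3 percentage points lower from compound 2 to compound 3 (within the scatter). For compound 3 the expected value is 84%, with an estimated range of 72% to 94%.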

Compound 3, percent of the compound remaining: 84%
For compound 3 middle estimate and measured number coincide at the digits printed; the measured number falls inside the stated range.
By their numbers in this assay, from the lowest: compounds 1, 3 and 2 (each within the scatter of the next).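

Fluoro now joins chloro and trifluoromethyl on this aromatic carbon, and in this assay the exchange reads as a number 3 percentage points lower from compound 2 to compound 3 (within the scatter) and as a number 1 percentage points higher from compound 1 to compound 3 (within the scatter). The earlier pair covered only chloro and trifluoromethyl, whereas this third group adds the smallest substituent of the set, with a single heavy atom in place of the four of trifluoromethyl. Even so, all three steps among these compounds stay within the scatter, so the read-out does not separate the three groups at this position, and nothing measured here accounts for that.

All three groups contain a halogen, so it remains open whether a substituent of another kind on this carbon, such as an amine, a methoxy group or a carboxylic acid, would also leave the read-out within the scatter of these compounds. On these data alone, it is equally open whether the same holds when another part of the shared core is changed, since these compounds differ only at this one aromatic carbon.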